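This account rests on a few compounds, and the source may have more. Where it says the series, first, only, none or still open, it means among the compounds named here.

Working notes on the sulfonamide series.

Three compounds have numbers in a functional assay on U-937 cells (Homo sapiens) for cytotoxicity, read by MTT assay, with a stated time of 24 h; a higher number here means a weaker inhibitor, a lower number a stronger inhibitor. Compound 1 `COc1cc2nc(N3CCCC3)nc(NS(=O)(=O)C3CC3)c2cc1OC` gives 6.43 ug/mL. Compound 2 `COc1cc2nc(N3CCCC3)nc(NS(=O)(=O)c3cccc(C(F)(F)F)c3)c2cc1OC` gives 16 ug/mL. Compound 3 `COc1ccc(S(=O)(=O)Nc2nc(Cl)nc3cc(OC)c(OC)cc23)cc1C` gives 41.1 ug/mL, the highest of the three numbers: its gap to compound 2 and its gap to compound 1 both lie beyond the scatter. For the measured compounds named here, no single-point step links compound 3 to compound 1 or compound 2, since the group on the shared core differs as well, so only the values themselves are compared here.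

Compound 4 `COc1cc2nc(Cl)nc(NS(=O)(=O)c3cccs3)c2cc1OC` is not yet measured. It differs from compound 3 in one place: thiophen-2-yl in place of 4-methoxy-3-methylphenyl on a sulfonyl sulfur.

Going by the values given here, the only measured step that changes the group on the sulfonyl sulfur is a 2.5-fold higher number from compound 1 to compound 2 (0.40 log units; beyond the scatter), where the larger aromatic ring gave the higher number. The change to compound 4 goes the other way in size, from a nine-atom aromatic group to a five-atom one, though on a core with a different substituent and with a different pair of groups, so the step is taken as a weak guide only. A modest step toward a lower number is expected in this assay for compound 4, of the size a 1.9-fold lower number from compound 3 to compound 4 (0.27 log units; within the scatter). The estimate for compound 4 is therefore 22 ug/mL, with a range from 8 ug/mL to 60 ug/mL.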

Compound 4, half-maximal inhibitory concentration: 10.1 ug/mL
Beside the measured number, compound 4's estimate is 2.2-fold (0.34 log units) above it, within the range that was stated.
By their numbers in this assay, from the lowest: compounds 1, 4 and 2 (each within the scatter of the next, the first and the last beyond it); then compound 3.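

The group on the sulfonyl sulfur now has a readable effect on a second core: in this assay the step to the thiophen-2-yl group gives a 4.1-fold lower number from compound 3 to compound 4 (0.61 log units; beyond the scatter). For the compounds shown here, until now, the only step at this position was a 2.5-fold higher number from compound 1 to compound 2 (0.40 log units; beyond the scatter), on the core of compound 1, so the two steps together show that the number in this assay responds to this group on both cores, and in each pair the smaller group carries the lower number. That holds for these two pairs only, and the data shown offer no measured property that accounts for either step.

Going by these compounds alone, each core has only its own pair of groups, so it remains open whether thiophen-2-yl or cyclopropyl would give a similar step on the other core, and no single step isolates the chlorine from the pyrrolidine ring on the core. Also open, as far as these compounds go, is how a sulfonyl sulfur bearing a group of another kind, such as a simple aminoalkyl chain or a carboxylic acid on the aromatic ring, would read here.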